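Swapping a Hydroxyphenyl Arm for a Methoxyphenylethenyl Arm

A few compounds are considered here, and "the series" means these few. Any claim that something is new, unique, unknown or untested is made for them only; others in the source may bear on it.

Of the compounds shown here, three built on one shared core have been measured in an assay on mitochondria (strain BALB/c) for inhibition of glycerol-3-phosphate acyltransferase 1, mitochondrial (Mus musculus), read by scintillation counting, with a stated time of 10 min; a higher number here means a weaker inhibitor, a lower number a stronger inhibitor. Compound 1 `CCCCCCCCS(=O)(=O)Nc1cc(-c2ccc(Cl)cc2)ccc1C(=O)O` gives 18100 nM, compound 2 `CCCCCCCCS(=O)(=O)Nc1cc(-c2ccc(CCCC)cc2)ccc1C(=O)O` gives 15700 nM, and compound 3 `CCCCCCCCS(=O)(=O)Nc1cc(-c2ccccc2O)ccc1C(=O)O` gives 63100 nM. Compound 3 thus stands at the highest number of the three: a 3.5-fold higher number from compound 1 to compound 3 (0.54 log units; beyond the scatter) and a 4.0-fold higher number from compound 2 to compound 3 (0.60 log units; beyond the scatter), whereas a 1.2-fold lower number from compound 1 to compound 2 (0.06 log units; within the scatter).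

Compound 4 `CCCCCCCCS(=O)(=O)Nc1cc(/C=C/c2ccc(OC)cc2)ccc1C(=O)O` is the next step from compound 3: 2-(4-methoxyphenyl)ethenyl in place of 2-hydroxyphenyl on an aromatic carbon. Among the measured compounds shown here, no measured pair carries exactly this change, but the two steps that lead to compound 3 bear on it, since each exchanged an aryl group without a hydroxy group for the 2-hydroxyphenyl group and raised the number by a modest amount. The move to compound 4 runs the other way, removing that 2-hydroxyphenyl group in favour of an arm bearing a methoxy group and no hydroxy group, and adding a double bond between the two rings. On these data alone, a modest step toward a lower number in this assay is therefore expected, of roughly the size seen in those two steps, though the longer arm is untested and widens the range. Compound 4 is expected to give about 20000 nM, between 7000 nM and 60000 nM, which would mean a 3.2-fold lower number from compound 3 to compound 4 (0.50 log units; beyond the scatter).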

Compound 4, half-maximal inhibitory concentration: 38700 nM
The estimate for compound 4 lay 1.9-fold (0.29 log units) below the measured number; the range from low to high includes it.
By their numbers in this assay, from the lowest: compounds 2 and 1 (each within the scatter of the next); then compounds 4 and 3 (each within the scatter of the next).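

In this assay, 2-(4-methoxyphenyl)ethenyl in place of 2-hydroxyphenyl gives a 1.6-fold lower number from compound 3 to compound 4 (0.21 log units; within the scatter), so at this position, para to the carboxy group, the two arms are not told apart despite the added double bond and the loss of the hydrogen-bond donor. Among the compounds shown here, the steps from the other two compounds, a 2.1-fold higher number from compound 1 to compound 4 (0.33 log units; beyond the scatter) and a 2.5-fold higher number from compound 2 to compound 4 (0.39 log units; beyond the scatter), show that an arm without a hydroxy group is not enough to bring the number to that of compound 1 or compound 2, which the earlier steps alone could not show. Nothing at hand explains these differences.

The compounds shown leave open what the double bond and the methoxy group each contribute, as compound 4 carries both at once; a 4-methoxyphenyl group attached directly to the core, or a saturated two-carbon chain in place of the double bond, would separate the two. Also open, on these data alone, is how an amine or a carboxylic acid on this arm would read in this assay.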